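From thiophen-2-yl to thiophen-3-yl in compound 4

This account rests on a few compounds, and the source may have more. Where it says the series, first, only, none or still open, it means among the compounds named here.

In a functional assay on RS4-11 cells (Homo sapiens) for antiproliferative activity, read by MTT assay, with a stated time of 72 h (a higher number here means a weaker inhibitor, a lower number a stronger inhibitor), compound 1 `C=C(Br)C(=O)Nc1ccc2c(c1)/C(=C/c1cccs1)C(=O)N2` gives 12 nM, the lowest number measured, while compound 2 `C=C(Br)C(=O)Nc1ccc2c(c1)/C(=C\c1cccs1)C(=O)N2` gives 530 nM. Compound 3 `Nc1ccc2c(c1)C(=Cc1ccsc1)C(=O)N2` gives > 10000 nM, which is a limit of the assay. Compound 4 `C=C(Br)C(=O)Nc1ccc2c(c1)/C(=C/c1ccsc1)C(=O)N2` differs from compound 1 in one place: thiophen-3-yl in place of thiophen-2-yl on a double-bonded chain carbon bound to a double-bonded ring carbon. Among the measured compounds shown here, the only measured step, a 44-fold higher number from compound 1 to compound 2 (1.65 log units; beyond the scatter), is large, and it reflects (the fact that compounds 1 and 2 differ only in the configuration as drawn). For the measured compounds named here, the double bond of compound 4 is drawn as in compound 1, so that step offers no direct precedent for swapping the thiophene. Only a small rise is expected in this assay, within the scatter: a 1.7-fold higher number from compound 1 to compound 4 (0.22 log units; within the scatter). For compound 4 the estimated value is 20 nM, with an expected range of 6 nM to 80 nM.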

Compound 4, half-maximal inhibitory concentration: 190 nM
The estimate for compound 4 lay 9.5-fold (0.98 log units) below the measured number; the whole stated range lies below it.
By their numbers in this assay, from the lowest: compound 1; then compound 4; then compound 2. At a limit, above all of these: compound 3.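

In this assay, swapping thiophen-2-yl for thiophen-3-yl gives a 16-fold higher number from compound 1 to compound 4 (1.20 log units; beyond the scatter), so the way the thiophene is joined matters at this place. Compound 4 keeps the double bond as drawn in compound 1, which ties this step to the thiophene change alone and not to configuration. Nothing shown here accounts for the size of this step.

Going by these compounds, how a phenyl or furan-2-yl ring would fare at this place remains open. So does whether a thiophen-3-yl compound with the opposite double-bond configuration would follow the thiophen-2-yl pattern.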